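This account rests on a few compounds, and the source may have more. Where it says the series, first, only, none or still open, it means among the compounds named here.

Compound 1 `CC1=CC[C@H](C(C)(C)NC(=S)N/N=C/c2ccc(O)cc2)CC1`; compound 2 `CC1=CC[C@H](C(C)(C)NC(=S)N/N=C/c2ccc(N(C)C)cc2)CC1`; compound 3 `COc1cc(/C=N/NC(=S)NC(C)(C)[C@H]2CC=C(C)CC2)ccc1O`.

In a functional assay on PC-3 cells (Homo sapiens) for inhibition, read by sulforhodamine B assay, with a stated time of 48 h (on this read-out lower numbers stand for stronger inhibition of growth and higher numbers for weaker inhibition of growth), compound 1 gives 600 nM. Compound 3 gives 300 nM. For compound 2 the assay reports only a limit, < 40 nM, which is the limit of < 40 nM in this assay, at which 1 of the 3 values shown sits. Among the two plain numbers compound 1 stands highest, and the step of a 2.0-fold lower number from compound 1 to compound 3 (0.30 log units; within the scatter) is within the usual scatter.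

Compound 4 `CC1=CC[C@H](C(C)(C)NC(=S)N/N=C/c2ccc[nH]2)CC1` differs from compound 1 by 1H-pyrrol-2-yl in place of 4-hydroxyphenyl on a carbon with a double bond to nitrogen. The measured steps from compound 1 alter only a group attached to that ring: an at least 15-fold lower number from compound 1 to compound 2 (1.17 log units; beyond the scatter), while a 2.0-fold lower number from compound 1 to compound 3 (0.30 log units; within the scatter). Neither exchanges the ring itself, so they give no direct guide for this change. A step of no size beyond the scatter is therefore expected, a 1.2-fold higher number from compound 1 to compound 4 (0.07 log units; within the scatter), with wide uncertainty. Compound 4 is estimated at 700 nM, between 150 nM and 3000 nM.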

Compound 4, concentration for 50% growth inhibition: 2800 nM
Compound 4: middle estimate off by 4.0-fold (0.60 log units), on the low side, within the range that was stated.
By their numbers in this assay, from the lowest: compounds 3 and 1 (each within the scatter of the next); then compound 4. At a limit, below all of these: compound 2.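

Exchanging the ring itself, not only a group on it, matters on this carbon with a double bond to nitrogen: in this assay the change gives a 4.7-fold higher number from compound 1 to compound 4 (0.67 log units; beyond the scatter). Growth inhibition is therefore weaker with 1H-pyrrol-2-yl than with 4-hydroxyphenyl, and this is the only step shown that moves to a higher number beyond the scatter. Nothing measured here explains this loss.

As far as these compounds go, it remains open whether a furan or pyridine ring in the same place would behave like 1H-pyrrol-2-yl or like 4-hydroxyphenyl. From the compounds shown here alone, it also remains open whether adding a dimethylamino group to the pyrrole would restore growth inhibition.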